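Methol capping of the core hydroxy: compound 1 to compound 4

The source may hold more compounds than are shown below. What is called first, only, known or untested is meant among the compounds shown, and "the series" means these compounds.

Compound 1 `COc1ccc(CNC(=O)/C=C/c2coc3cc(O)ccc3c2=O)cc1` reaches only the limit of a functional assay on HeLa cells (Homo sapiens) for inhibition, read by MTT assay, with a stated time of 48 h (a higher number here means a weaker inhibitor, a lower number a stronger inhibitor), giving > 100000 nM, so no number stands for it. The same holds for compound 2 `COc1ccc2c(=O)c(/C=C/C(=O)Nc3ccccc3)coc2c1`, which also gives a limit of > 100000 nM. Compound 3 `COc1ccc2c(=O)c(/C=C/C(=O)Nc3cc(C)ccc3C)coc2c1` gives 58400 nM. Within the data shown here, the one measured step, an at least 1.7-fold lower number from compound 2 to compound 3 (0.23 log units; that floor lies within the scatter), changes the amide nitrogen side and does not touch the core oxygen; it is also the weaker of the two evidences, since the limit of > 100000 nM in this assay, at which 2 of the 3 values shown sit, dominates the set. Compound 4 `COc1ccc(CNC(=O)/C=C/c2coc3cc(OC)ccc3c2=O)cc1` differs from compound 1 by methyl in place of hydrogen on an oxygen on an aromatic ring. Nothing measured bears on this change; compounds 2 and 3 carry methoxy on the core and remain weak. Compound 4 is therefore expected near the limit, with a step that the limit leaves unreadable from compound 1 to compound 4 that cannot be resolved. The estimate for compound 4 is 120000 nM, ranging from 30000 nM to 500000 nM.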

Compound 4, half-maximal inhibitory concentration: > 100000 nM
Compound 4 was reported as a limit; the forecaster's own chance of this, stated with the estimate: 65%; the middle value is on the limit's open side.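

In this assay compound 4 gives > 100000 nM, which is a limit of the assay. Methoxy in place of hydroxy on the core therefore brings no readable gain, and the steps to compound 4 from compound 1 and compound 2 cannot be read, with the set still dominated by one value: the limit of > 100000 nM in this assay, at which 3 of the 4 values shown sit. With 4-methoxybenzyl in place of 2,5-dimethylphenyl on the amide nitrogen, the result is an at least 1.7-fold higher number from compound 3 to compound 4 (0.23 log units; that floor lies within the scatter).

As far as these compounds go, whether the hydroxy-to-methoxy change has any effect at all remains open. Also open, from the compounds shown here alone, is whether a longer chain ending in an amine on the core oxygen, or a carboxylic acid on the benzyl ring, would give a value inside the assay's range.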